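The source may report more compounds than this note shows. Statements on the series, on what has been measured and on what is new or still open speak of the compounds shown alone.

In a functional assay on SW480 cells (Homo sapiens) for antiproliferative activity, read by MTT assay, with a stated time of 48 h (a lower number here means a stronger inhibitor, a higher number a weaker inhibitor), the measured compounds read:

Compound 1 `CCCC(CCO)n1cnc2c(Cl)nc(F)nc21`: 17200 nM
Compound 2 `CCCCCCC(CCO)n1cnc2c(Cl)nc(F)nc21`: 12900 nM
Compound 3 `CCCCCCCC(CCO)n1cnc2c(Cl)nc(F)nc21`: 26100 nM

Compound 3 lies within the scatter of compound 1, with a 1.5-fold higher number from compound 1 to compound 3 (0.18 log units; within the scatter). Against compound 2 it shows a 2.0-fold higher number from compound 2 to compound 3 (0.31 log units; beyond the scatter), the only measured step that clears the scatter. Compound 4 `CCCCCCCCCC(CCO)n1cnc2c(Cl)nc(F)nc21` differs from compound 3 as follows: ethyl in place of hydrogen on a saturated chain carbon, eight bonds along the chain from an aromatic nitrogen. Three steps on the same chain bear on this change: a 1.3-fold lower number from compound 1 to compound 2 (0.12 log units; within the scatter), a 1.5-fold higher number from compound 1 to compound 3 (0.18 log units; within the scatter) and a 2.0-fold higher number from compound 2 to compound 3 (0.31 log units; beyond the scatter). They are small and do not share one direction, so this assay is expected to show little change, at most a slight rise. The expected step is a 1.1-fold higher number from compound 3 to compound 4 (0.06 log units; within the scatter), which would not clear the scatter. The estimate for compound 4 is 30000 nM, with an expected range from 12000 nM to 70000 nM.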

Compound 4, half-maximal inhibitory concentration: 12500 nM
Compound 4: the middle estimate sits 2.4-fold (0.38 log units) above what was measured; measured number inside the range.
By their numbers in this assay, from the lowest: compounds 4, 2, 1 and 3 (each within the scatter of the next, the first and the last beyond it).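

In this assay, the ethyl on the saturated chain carbon gives a 2.1-fold lower number from compound 3 to compound 4 (0.32 log units; beyond the scatter), which runs against the earlier 2.0-fold higher number from compound 2 to compound 3 (0.31 log units; beyond the scatter), so lengthening this chain does not push the number one way. Compound 4 also sits level with the shorter chains, with a 1.0-fold lower number from compound 2 to compound 4 (0.01 log units; within the scatter) and a 1.4-fold lower number from compound 1 to compound 4 (0.14 log units; within the scatter); across the four compounds, only compound 3 goes against a flat reading. Nothing available explains this turn. From the compounds shown here alone, whether a longer chain would hold this level, and what an amine or a carboxylic acid on the chain would do to the number, remains open.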